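This account rests on a few compounds, and the source may have more. Where it says the series, first, only, none or still open, it means among the compounds named here.

For the measured compounds named here, in an ADME assay on MT4 cells (Homo sapiens) for cytotoxicity, read by MTT assay, with a stated time of 5 days (a lower number here means that less compound is tolerated, a higher number that more compound is tolerated), compound 1 `Cc1cc(C)cc(S(=O)(=O)c2c(C(=O)N[C@@H]3CCNC3)[nH]c3ccc(Cl)cc23)c1` gives 37300 nM, the higher of the two plain numbers so far. Compound 2 `Cc1cc(C)cc(S(=O)(=O)c2c(C(=O)N[C@H]3CCNC3)[nH]c3ccc(Cl)cc23)c1`, which differs from it only in configuration as drawn, gives 10000 nM, which is a 3.7-fold lower number from compound 1 to compound 2 (0.57 log units; beyond the scatter). Compound 3 `Cc1cc(C)cc(S(=O)(=O)c2c(C(=O)N[C@@H]3CCN(Cc4ccccc4F)C3)[nH]c3ccc(Cl)cc23)c1` reports only a limit, > 231000 nM. Compound 4 `Cc1cc(C)cc(S(=O)(=O)c2c(C(=O)N[C@@H]3CCN(Cc4ccccc4C#N)C3)[nH]c3ccc(Cl)cc23)c1` carries 2-cyanobenzyl on the ring nitrogen instead: 2-cyanobenzyl in place of hydrogen on an amine nitrogen in a ring. The closest guide is the swap of hydrogen for 2-fluorobenzyl on that same nitrogen, which gave an at least 6.1-fold higher number from compound 1 to compound 3 (0.79 log units; beyond the scatter), so a clearly higher number is expected in this assay. The expected change is a 3.2-fold higher number from compound 1 to compound 4 (0.51 log units; beyond the scatter). For compound 4 the estimate is 120000 nM, with an expected range of 35000 nM to 300000 nM.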

Compound 4, half-maximal cytotoxic concentration: >= 186000 nM
Compound 4: no number, only a limit; the forecaster's own chance of this, stated with the estimate: 50%; middle value at least 1.5-fold (0.19 log units) from the limit.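

Compound 4 shows that the rise seen with 2-fluorobenzyl on this ring nitrogen is not confined to that one group: in this assay, 2-cyanobenzyl in place of hydrogen gives an at least 4.9-fold higher number from compound 1 to compound 4 (0.69 log units; beyond the scatter). The result for compound 4 is a limit and not a number: the limit of >= 186000 nM in this assay, at which 1 of the 4 values shown sits. Compound 3 also reports a limit, and the step of cyano in place of fluoro cannot be read.

As far as these compounds go, it remains open whether a smaller group on this nitrogen, such as methyl, or plain benzyl would raise the number too. Also open, from the compounds shown here alone, is whether 2-cyanobenzyl on the ring nitrogen of compound 2 would do the same.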